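The source may report more compounds than this note shows. Statements on the series, on what has been measured and on what is new or still open speak of the compounds shown alone.

Measured so far:
- compound 1, `NC(=O)c1ccccc1NC(=O)c1cn(-c2ccccc2)nc1-c1ccc(Cl)cc1`, in a functional assay on the whole organism (strain albino) for inhibition, with Rattus norvegicus as the target, read by paw edema, with stated times of 30 min and 1 h, at a dose of 50 mg/kg by the oral route; on this read-out higher numbers stand for more inhibition at the one dose given (going by the name of the read-out) and lower numbers for less inhibition: 1.96%
- compound 2, `CC(=O)Nc1ccc(OC(=O)c2cn(-c3ccccc3)nc2-c2ccc(Cl)cc2)cc1`, in this assay: 17.8%

Compound 2 stands highest of the two numbers; its nearest neighbour, compound 1, sits well below it, by a gap that lies beyond the usual scatter of this kind of measurement. Compound 3, `CC(=O)Nc1ccc(OC(=O)c2cn(-c3ccccc3)nc2-c2ccc(C)cc2)cc1`, is not yet measured. It differs from compound 2 in one place: methyl in place of chloro on an aromatic carbon. Among the compounds with values here, no step between measured compounds shows what such an exchange does here, so compound 3 is expected to stay close to compound 2, with a step of a number 2.8 percentage points lower from compound 2 to compound 3 (within the scatter) that is not beyond the scatter. The estimate for compound 3 in this assay is 15%, in the range 4% to 27%.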

Compound 3, a percentage reported as inhibition, in the whole organism at one dose (the size of the read-out at that dose, not a potency): 2.94%
The estimate for compound 3 lay 12.1 percentage points above the measured number; the whole stated range lies above it.
By their numbers in this assay, from the lowest: compounds 1 and 3 (each within the scatter of the next); then compound 2.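

Swapping chloro for methyl on the aromatic carbon para to a large group gives a number 14.9 percentage points lower from compound 2 to compound 3 (beyond the scatter) in this assay. So this position is not indifferent to a change of a single heavy atom, and of these two groups, only chloro goes with the higher inhibition at this dose. Nothing at hand explains why the exchange has this effect. On these data alone, whether an amine, a methoxy group or a longer chain such as propyl at this position would restore or raise the inhibition remains open. A single pair also cannot show whether the same exchange would act alike on another core.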